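Hydroxy Substitution on a Thiazolidinedione Scaffold: An Expected Potency

The source may report more compounds than this note shows. Statements on the series, on what has been measured and on what is new or still open speak of the compounds shown alone.

Measured compounds:
- compound 1, `CCCN1C(=O)/C(=C\c2ccncc2)SC1=S`: 800 nM
- compound 2, `Cc1cc(C)cc(CC2SC(=O)NC2=O)c1`: "not determined" (no result reported)

In an assay on isolated protein for inhibition of Amine oxidase [flavin-containing] B (Homo sapiens), read by Amplex Red (a lower number here means a stronger inhibitor, a higher number a weaker inhibitor), compound 1 gives 800 nM. Compound 2, `Cc1cc(C)cc(CC2SC(=O)NC2=O)c1`, was carried through the same study, but for compound 2 the result in this assay is "not determined" (no result reported), so its standing cannot be placed against compound 1 or anything else. The account turns on the step from compound 2 to compound 3, `Cc1cc(CC2SC(=O)NC2=O)cc(C)c1O`. The change is hydroxy in place of hydrogen on an aromatic carbon: hydroxy enters on an aromatic carbon of a six-membered aromatic ring of carbon only, ortho to two methyl groups, para to a group of 8 heavy atoms. Among the compounds with values here, because compound 2 has no value in this assay, no step can be measured and no direction can be drawn from the numbers; the only anchor is compound 1 at 800 nM. With that anchor alone, no step beyond the usual scatter is expected in either direction for compound 3. Compound 3 is estimated at 2000 nM, with a range from 300 nM to 15000 nM.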

Compound 3, half-maximal inhibitory concentration: 16100 nM
Compound 3: middle estimate off by 8.1-fold (0.91 log units), on the low side; the measured number lies above the stated range.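

In this assay, within the data shown here, compound 3 gives 16100 nM but no step from compound 2 to compound 3 can be read from that number. The compounds shown leave open what hydroxy in place of hydrogen on an aromatic carbon does to the result in this assay on this scaffold. No available evidence bears on this result.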